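Bromo in place of 2-hydroxyphenyl on the shared core

The source may report more compounds than this note shows. Statements on the series, on what has been measured and on what is new or still open speak of the compounds shown alone.

Within the data shown here, compound 1 `O=C(NO)c1ccc(/C=C/c2ccnc(-c3ccccc3O)c2)cc1` gives 1420 nM in a functional assay on MGC-803 cells (Homo sapiens) for antiproliferative activity, read by CellTiter-Glo, with a stated time of 72 h (a lower number here means a stronger inhibitor, a higher number a weaker inhibitor), the only number obtained so far. Compound 2 `O=C(NO)c1ccc(/C=C/c2ccnc(-c3ccc(C(F)(F)F)cc3)c2)cc1` reports only the limit of this assay, > 10000 nM. Compound 3 `Cc1ccc(-c2cc(/C=C/c3ccc(C(=O)NO)cc3)c(F)cn2)cc1` likewise reports only the limit, > 10000 nM. Compound 1 therefore stands alone as a measured number, while the other two values sit at the limit (the limit of > 10000 nM in this assay, at which 2 of the 3 values shown sit). Compound 4 `O=C(NO)c1ccc(/C=C/c2ccnc(Br)c2)cc1` carries the change (bromo in place of 2-hydroxyphenyl on an aromatic carbon). Among the measured compounds shown here, no step between measured compounds is known, so its size is uncertain; compounds 2 and 3, each bearing a different aromatic group, both reach the limit, whereas compound 1 does not. For compound 4 a loss of potency beyond the scatter is expected, a 3.2-fold higher number from compound 1 to compound 4 (0.50 log units; beyond the scatter). Compound 4 is estimated at 4500 nM, in the range 1200 nM to 15000 nM.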

Compound 4, half-maximal inhibitory concentration: > 10000 nM
Compound 4: only a limit was reported; the forecaster's own chance of this, stated with the estimate: 30%; at least 2.2-fold (0.34 log units) between middle value and limit.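

In this assay, bromo in place of 2-hydroxyphenyl on this aromatic carbon, next to the ring nitrogen, gives an at least 7.0-fold higher number from compound 1 to compound 4 (0.84 log units; beyond the scatter). On these data alone, compound 4 gives only a limit of the assay, > 10000 nM, so the true size of this step remains unknown. A small bromo without a ring here therefore joins two aryl-bearing compounds at the ceiling, leaving compound 1 as the only measured number: the limit of > 10000 nM in this assay, at which 3 of the 4 values shown sit.

As far as these compounds go, how far compound 4 lies past the limit stays open. Also open, from the compounds shown here alone, is how an unsubstituted phenyl or an amine at this carbon would read, and so whether the hydroxyl of compound 1 matters.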